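Dropping the fluoro group: from compound 2 to compound 4

The source may report more compounds than this note shows. Statements on the series, on what has been measured and on what is new or still open speak of the compounds shown alone.

Three compounds have numbers in a functional assay on RPMI-8226 cells (Homo sapiens) for inhibition, read by sulforhodamine B assay, with a stated time of 48 h; a higher number here means a weaker inhibitor of growth, a lower number a stronger inhibitor of growth. Compound 1 `N=C(N)c1ccc(-c2ccc(-c3ccc(F)cc3)s2)cc1` gives 799 nM, compound 2 `COc1cc(OC)cc(-c2ccc(-c3ccc(C(=N)N)c(F)c3)s2)c1` gives 246 nM and compound 3 `COc1ccc(-c2ccc(-c3ccc(C(=N)N)c(F)c3)s2)cc1` gives 2510 nM. Compound 2 holds the lowest number of the three; its nearest neighbour is compound 1, whose number lies beyond the scatter above it, and compound 3 lies further still, so compound 2 is the strongest inhibitor of growth among the three measured.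

The next compound, compound 4 `COc1cc(OC)cc(-c2ccc(-c3ccc(C(=N)N)cc3)s2)c1`, has not yet been measured in this assay. It differs from compound 2 in one place: hydrogen in place of fluoro on an aromatic carbon. The fluoro leaves and hydrogen enters, on an aromatic carbon of a six-membered aromatic ring of carbon only, ortho to a group of 3 heavy atoms and meta to a large group. Among the compounds with values here, no measured pair in the set shows this change on its own; compound 1 lacks the fluoro but differs from compound 2 elsewhere as well, so the number of compound 1, 799 nM, cannot be read as a guide to this step.

The step is expected to be small, a 1.6-fold higher number from compound 2 to compound 4 (0.21 log units; within the scatter), in the direction of a weaker inhibitor and possibly within the scatter. Compound 4 is estimated at 400 nM, with a range from 150 nM to 1100 nM.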

Compound 4, concentration for 50% growth inhibition: 1460 nM
Estimate against measurement, compound 4: 3.7-fold (0.56 log units) below; measured number outside the range, above it.
By their numbers in this assay, from the lowest: compound 2; then compounds 1, 4 and 3 (each within the scatter of the next, the first and the last beyond it).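

In this assay, within the data shown here, the aromatic carbon ortho to a group of 3 heavy atoms and meta to a large group now has a measured single change: hydrogen in place of fluoro gives a 5.9-fold higher number from compound 2 to compound 4 (0.77 log units; beyond the scatter) and is the first step that isolates one place. The step is modest but beyond the scatter, so for this pair the fluoro goes with the stronger inhibitor of growth and its loss cannot be treated as neutral. Nothing measured on these compounds accounts for the step, which stands as an observation only. 

From the compounds shown here alone, the reading rests on a single pair with the shared core of compound 2 and compound 4, and whether the fluoro counts the same way alongside the other aryl groups stays open, as compound 1 and compound 3 have no partner here that differs from them in one place. Also open, going by these compounds, is whether a chlorine, a hydroxyl or an amine on the same aromatic carbon would give a number nearer that of compound 2 or that of compound 4.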